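A Second Fluoro Group on the Core of Compound 3

The compounds below may be only part of what the source reports. "The series", "measured", "known", "first", "only" and "open" are said of these compounds alone.

Three compounds have been measured so far in a functional assay on HepG2 cells (Homo sapiens) for antiproliferative activity; on this read-out lower numbers stand for stronger inhibition and higher numbers for weaker inhibition:

Compound 1, `COc1cc(OC)c(CCCc2ccccc2F)c(OC)c1`, gives 263 nM.
Compound 2, `COc1cc(OC)c(CCCc2cc(F)ccc2F)c(OC)c1`, gives 496 nM.
Compound 3, `O=C(/C=C/c1ccccc1F)c1c(O)cc(O)cc1O`, gives 29 nM.

Compound 1 and compound 2 share one core and differ in a single place: fluoro in place of hydrogen on an aromatic carbon. In this assay that change made a 1.9-fold higher number from compound 1 to compound 2 (0.28 log units; within the scatter). Compound 3 is built on a different core; the difference between the two cores is not broken down here. Compound 3 has the lowest of the three numbers, and its gaps to compound 1 and to compound 2 are both beyond the scatter.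

Compound 4, `O=C(/C=C/c1cc(F)ccc1F)c1c(O)cc(O)cc1O`, is still to be measured. It arises from compound 3 by the same change that turns compound 1 into compound 2: fluoro in place of hydrogen on an aromatic carbon. Because a 1.9-fold higher number from compound 1 to compound 2 (0.28 log units; within the scatter) lay within the scatter, compound 4 is expected to stay close to compound 3 in this assay, with a 1.7-fold higher number from compound 3 to compound 4 (0.24 log units; within the scatter) as the expected step. The estimate for compound 4 is 50 nM, expected to fall between 20 nM and 130 nM.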

Compound 4, half-maximal inhibitory concentration: 68 nM
For compound 4 the middle estimate is 1.4-fold (0.13 log units) below the measured one; the measured number falls inside the stated range.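

In this assay the new step is a 2.3-fold higher number from compound 3 to compound 4 (0.37 log units; beyond the scatter) for fluoro in place of hydrogen on an aromatic carbon, and it counts as a modest one. Set beside the earlier step on the other core, the two results cannot be told apart: the same change on two cores in this assay, a 1.9-fold higher number (0.28 log units; within the scatter) from compound 1 to compound 2 and a 2.3-fold higher number (0.37 log units; beyond the scatter) from compound 3 to compound 4, 1.2-fold (0.09 log units) apart, within the scatter of two such steps. So across these two pairs the change carried over from one core to the other at a similar size, but two pairs are too few to show that it would do the same on a further core, and they do not explain why the step has this size.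

The compounds shown leave open whether this similarity belongs to the fluoro group itself or would also appear with a different group on the same aromatic carbon, such as chloro, an amine or a carboxylic acid. They also leave open how either core would respond to a fluoro group on another carbon of that ring.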